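A few compounds are considered here, and "the series" means these few. Any claim that something is new, unique, unknown or untested is made for them only; others in the source may bear on it.

Working notes on the series. All three compounds share one core with two chains attached to it. Within the data shown here, compound 1 `OCC#CCSc1cnc2ccccc2c1[Se]CC#CCO` is the first measured member; in a functional assay on B16 cells (Mus musculus) for cytotoxicity, read by sulforhodamine B assay, with a stated time of 72 h (a lower number here means a stronger inhibitor, a higher number a weaker inhibitor), compound 1 gives 4.3 ug/mL. Compound 2 `C#CCSc1cnc2ccccc2c1[Se]CC#CCBr` is the second; in this assay compound 2 gives 4.2 ug/mL. Among the measured compounds shown here, of the two numbers so far compound 2 has the lower one, but the gap to compound 1 lies within the scatter, so the two are read as equal, and no step between measured compounds that differ in a single place is available to calibrate the effect of any change.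

Compound 3 `C#CCSc1cnc2ccccc2c1[Se]CC#CCO` is the third member, not yet measured in this assay. The change from compound 2 to compound 3 is hydroxy in place of bromo on a saturated chain carbon bound to a triple-bonded carbon. Compound 1, which also carries hydroxy, gives 4.3 ug/mL in this assay, a number no different from that of compound 2; the step of a 1.0-fold higher number from compound 2 to compound 3 (0.01 log units; within the scatter) is therefore expected to show no direction beyond the scatter. Compound 3 is estimated at 4.3 ug/mL in this assay, with a range from 2.2 ug/mL to 8.5 ug/mL.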

Compound 3, concentration for 50% inhibition: 3.6 ug/mL
The estimate for compound 3 lay 1.2-fold (0.08 log units) above the measured number; the range from low to high includes it.
By their numbers in this assay, from the lowest: compounds 3, 2 and 1 (each within the scatter of the next).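

In this assay, among these compounds, hydroxy in place of bromo on a saturated chain carbon bound to a triple-bonded carbon gives a 1.2-fold lower number from compound 2 to compound 3 (0.07 log units; within the scatter) and so supplies the first reading of a single change: at this place, the exchange of these two groups does not move the number beyond the scatter. Hydrogen in place of hydroxymethyl on a triple-bonded carbon gives a 1.2-fold lower number from compound 1 to compound 3 (0.08 log units; within the scatter) and so shows that this second single change also stays inside the scatter, which means that neither of the two places has yet produced a step that can be given a direction. No other measurement accompanies these steps that could account for their size.

From the compounds shown here alone, it remains open whether an amine or a carboxylic acid on that saturated chain carbon, or a longer chain ending in hydroxy, would produce a step beyond the scatter. Also open, going by these compounds, is whether either change would keep the same small size in any test other than this assay.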